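A few compounds are considered here, and "the series" means these few. Any claim that something is new, unique, unknown or untested is made for them only; others in the source may bear on it.

Of the compounds shown here, two from this series have been tested in a functional assay on ACHN cells (Homo sapiens) for inhibition, read by sulforhodamine B assay, with a stated time of 48 h; a lower number here means a stronger inhibitor of growth, a higher number a weaker inhibitor of growth. Compound 1 `O=C(Nc1cccc(-n2cc(-c3ccncc3)c(-c3ccc(Cl)c(O)c3)n2)c1)Nc1ccc(Cl)c(Cl)c1` gives 1040 nM in this assay, and compound 2 `COc1cc(-c2nn(-c3cccc(NC(=O)Nc4ccc(Cl)c(C(F)(F)F)c4)c3)cc2-c2ccncc2)ccc1Cl` gives 1100 nM. These two results sit within the scatter of each other, so the data show no difference between them in this assay.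

Compound 3 `O=C(Nc1cccc(-n2cc(-c3ccncc3)c(-c3ccc(Cl)c(O)c3)n2)c1)Nc1ccc(Cl)c(C(F)(F)F)c1` is the next compound to be tested. It differs from compound 2 in one place: hydrogen in place of methyl on an oxygen on an aromatic ring. Going by the values given here, no measured pair in this set shows how such a change affects the readout on its own, so no direct precedent exists for this step.

Compound 3 is expected to give 1000 nM, with a range from 400 nM to 2500 nM, because compound 1, which carries the 4-chloro-3-hydroxyphenyl group, gives 1040 nM. The expected step from compound 2 to compound 3 is therefore estimated as a 1.1-fold lower number from compound 2 to compound 3 (0.04 log units; within the scatter), no change beyond the scatter.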

Compound 3, concentration for 50% growth inhibition: 913 nM
Beside the measured number, compound 3's estimate is 1.1-fold (0.04 log units) above it; the measured number falls inside the stated range.
By their numbers in this assay, from the lowest: compounds 3, 1 and 2 (each within the scatter of the next).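

In this assay, going by these compounds alone, the move from methoxy to hydroxy on the 4-chloro-3-methoxyphenyl group gives the first direct reading at this oxygen on the aromatic ring: the step is a 1.2-fold lower number from compound 2 to compound 3 (0.08 log units; within the scatter) and so cannot be told apart from no change. The second single change, trifluoromethyl in place of chloro on an aromatic carbon, gives a 1.1-fold lower number from compound 1 to compound 3 (0.06 log units; within the scatter) and is likewise not distinguishable from no change. These compounds therefore show that, in this setting, either swap can be made without a readable shift in growth inhibition, and no outside measurement is at hand to account for this.

Each change is seen only once, so the result may not hold on a different core. Going by these compounds, whether a larger group on that oxygen, such as a longer alkyl chain, or an amine in place of the hydroxy would shift the number remains open.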